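The source may report more compounds than this note shows. Statements on the series, on what has been measured and on what is new or still open speak of the compounds shown alone.

Measured in a functional assay on HL-60 cells (Homo sapiens) for antiproliferative activity, read by MTT assay; on this read-out higher numbers stand for weaker inhibition and lower numbers for stronger inhibition:
compound 1 `O=C(N/N=C/c1ccccc1)c1cn(C2CC2)c2cc(N/N=C/c3ccccc3)c(F)cc2c1=O`: <= 25000 nM, a limit
compound 2 `O=C(N/N=C/c1ccccc1)c1cn(C2CC2)c2cc(N3CCNCC3)c(F)cc2c1=O`: <= 25000 nM, a limit

Compound 2 has no number, only the limit <= 25000 nM. Both compounds sit at the same limit: the limit of <= 25000 nM in this assay, at which 2 of the 2 values shown sit. For the measured compounds named here, the one measured step, a step that the two limits leave unreadable from compound 1 to compound 2, lies at another place and has no readable size. Compound 3 `COc1ccc(/C=N/NC(=O)c2cn(C3CC3)c3cc(N4CCNCC4)c(F)cc3c2=O)cc1O` carries 3-hydroxy-4-methoxyphenyl in place of phenyl on a carbon with a double bond to nitrogen. Going by the values given here, no measured step bears on this change, so neither a size nor a direction can be drawn from the data, and no shift beyond the scatter is firmly expected in this assay. The expected step, a loose estimate, is a step that the limit leaves unreadable from compound 2 to compound 3. The estimate for compound 3 is 6000 nM, with an expected range of 1000 nM to 25000 nM.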

Compound 3, half-maximal inhibitory concentration: <= 25000 nM
Compound 3: a limit, no number; the forecaster's own chance of this, stated with the estimate: 35%; the middle value does not contradict the limit.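

No step can be read from compound 2 to compound 3 in this assay, as the values stand at one limit: the limit of <= 25000 nM in this assay, at which 3 of the 3 values shown sit. The compounds shown leave open the size and direction of any change on 3-hydroxy-4-methoxyphenyl in place of phenyl.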